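Amide nitrogen variation from compound 3 to compound 4

The source may hold more compounds than are shown below. What is called first, only, known or untested is meant among the compounds shown, and "the series" means these compounds.

Measured compounds:
compound 1 `COc1cc2c(cc1OC)C(CC(=O)O)CC2`: 27.5%
compound 2 `CCCNC(=O)CC1CCc2cc(OC)c(OC)cc21`: 29%
compound 3 `COc1cc2c(cc1OC)C(CC(=O)NC(C)C)CC2`: 30.4%

All three numbers come from a functional assay on the whole organism (strain Wistar) for inhibition, with Rattus norvegicus as the target, read by paw edema, with stated times of 60 min and 3 h, at a dose of 100 mg/kg by the oral route; on this read-out lower numbers stand for less inhibition and higher numbers for more inhibition at the one dose given (going by the name of the read-out). Compound 3 holds the highest of the three numbers, yet this means little: a number 1.4 percentage points higher from compound 2 to compound 3 (within the scatter) and a number 2.9 percentage points higher from compound 1 to compound 3 (within the scatter) both lie within the scatter, so no order among compounds 1, 2 and 3 can be read from them. The first two steps, a number 1.5 percentage points higher from compound 1 to compound 2 (within the scatter) and a number 2.9 percentage points higher from compound 1 to compound 3 (within the scatter), show that replacing the hydroxy on the carbonyl carbon by either alkylamino group leaves the read-out essentially unchanged.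

Compound 4 `CCCCNC(=O)CC1CCc2cc(OC)c(OC)cc21` differs from compound 3 in one place: butyl in place of isopropyl on an amide-type nitrogen. The step that bears on this change most directly is a number 1.4 percentage points higher from compound 2 to compound 3 (within the scatter), a swap of one three-carbon group for another on the same amide-type nitrogen, and it stayed within the scatter. Going from a branched three-carbon to a straight four-carbon group is a somewhat larger change, but nothing among the measured steps suggests that the size or shape of the group on this nitrogen moves this read-out beyond its scatter.

The expected step is therefore a number 1.4 percentage points lower from compound 3 to compound 4 (within the scatter), i.e. no change beyond the scatter. For compound 4 the estimate in this assay is 29%, within the range 19% to 39%.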

Compound 4, a percentage reported as inhibition, in the whole organism at one dose (the size of the read-out at that dose, not a potency): 27.5%
The estimate for compound 4 lay 1.5 percentage points above the measured number, and the stated range covers the measured number.
By their numbers in this assay, from the lowest: compounds 1, 4, 2 and 3 (each within the scatter of the next).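

In this assay, butyl on the amide-type nitrogen gives a step that stays within the scatter, a number 2.9 percentage points lower from compound 3 to compound 4 (within the scatter), and the same holds for the straight-chain comparison, a number 1.5 percentage points lower from compound 2 to compound 4 (within the scatter), so isopropyl, propyl and butyl cannot be told apart at this position. With no change at the digits printed from compound 1 to compound 4 (within the scatter), butylamino joins propylamino and isopropylamino as a replacement for hydroxy on a carbonyl carbon that leaves the read-out within the scatter of the carboxylic acid, and neither the acid nor any of the three amides stands out at the one dose given. Nothing at hand accounts for these groups giving such similar numbers.

The compounds shown leave open whether a longer chain such as octyl, a ring such as cyclohexyl or benzyl, or a chain ending in a dimethylamino group on this nitrogen would move the read-out beyond its scatter. They also leave open whether replacing the methoxy groups of the shared core with hydroxy groups would separate these amides from the carboxylic acid.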